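Hydroxy removal on a trimethoxyphenyl pyrazoline series

The source may report more compounds than this note shows. Statements on the series, on what has been measured and on what is new or still open speak of the compounds shown alone.

Measured compounds:
compound 1 `CCCOC(=O)N1N=C(c2ccccc2)CC1c1cc(OC)c(OC)c(OC)c1` — > 10000 nM
compound 2 `CCCOC(=O)N1N=C(c2cccc(O)c2)CC1c1cc(OC)c(OC)c(OC)c1` — > 10000 nM
compound 3 `COC(=O)N1N=C(c2ccccc2)CC1c1ccc(OC)c(O)c1` — 7520 nM

In a functional assay on HeLa cells (Homo sapiens) for antiproliferative activity, read by MTT assay, with a stated time of 48 h (on this read-out lower numbers stand for stronger inhibition of growth and higher numbers for weaker inhibition of growth), compound 1 sits at a limit of the assay. Compound 2 also sits at a limit in this assay. Compound 3 is the only one of the three with a number in this assay. The change from compound 2 to compound 1 is hydrogen in place of hydroxy on an aromatic carbon; the step that the two limits leave unreadable from compound 2 to compound 1 cannot be read because both ends are limits (the limit of > 10000 nM in this assay, at which 2 of the 3 values shown sit). The difference between the cores of compound 2 and compound 3 is not broken down here.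

Compound 4 `COC(=O)N1N=C(c2ccccc2)CC1c1ccc(OC)cc1` is not yet measured. It differs from compound 3 by hydrogen in place of hydroxy on an aromatic carbon, the same kind of change as from compound 2 to compound 1, but here the hydroxy leaves from a carbon ortho to a methoxy group rather than from a plain phenyl ring. No readable step for this change exists, so the expectation rests on the value of compound 3 in this assay, 7520 nM, with a step of a 2.0-fold higher number from compound 3 to compound 4 (0.30 log units; within the scatter) expected. Compound 4 is estimated at 15000 nM, between 5000 nM and 50000 nM.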

Compound 4, concentration for 50% growth inhibition: 12700 nM
Compound 4: middle estimate off by 1.2-fold (0.07 log units), on the high side, and the stated range covers the measured number.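

In this assay, hydrogen in place of hydroxy on an aromatic carbon ortho to a methoxy group gives a 1.7-fold higher number from compound 3 to compound 4 (0.23 log units; within the scatter), so on this core the change leaves no difference that can be told from the usual scatter. Compound 2 and compound 1 both stand at a limit, so the same kind of change on their core cannot be read: the limit of > 10000 nM in this assay, at which 2 of the 4 values shown sit.

The series therefore holds a single readable step for this change, on one core, and this does not show that the result carries over to the core of compound 1 or to any other core.

Still open, as far as these compounds go, is whether an amine or a carboxylic acid in place of the hydroxy on the core of compound 3 would give a step beyond the scatter. Also open, from the compounds shown here alone, is whether a longer chain in place of the methoxy group on that core would change the number, and whether any compound on the core of compound 1 would give a number and not a limit.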